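Trading a chlorinated benzyl ether for a fluorinated one

The compounds below may be only part of what the source reports. "The series", "measured", "known", "first", "only" and "open" are said of these compounds alone.

Of the compounds shown here, three sharing one core have been measured in an assay on mitochondria for inhibition of Amine oxidase [flavin-containing] B (Rattus norvegicus); on this read-out higher numbers stand for weaker inhibition and lower numbers for stronger inhibition. Compound 1 `C[C@H](NCc1ccc(OCc2ccc(Cl)cc2)cc1)C(N)=O` gives 2200 nM. Compound 2 `NC(=O)[C@H](CO)NCc1ccc(OCc2ccc(Cl)cc2)cc1` gives 1100 nM, and compound 3 `NC(=O)[C@@H](CO)NCc1ccc(OCc2cccc(Cl)c2)cc1` gives 110 nM. Among the measured compounds shown here, the only single-point step among them, a 2.0-fold lower number from compound 1 to compound 2 (0.30 log units; within the scatter), puts a hydroxy in place of a hydrogen on a saturated chain carbon two bonds along the chain from an amine nitrogen and a carbonyl carbon. Compound 2 thus stands second highest of the three numbers, close to compound 1 and far from compound 3, which differs from it in more than one place.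

Compound 4 `NC(=O)[C@H](CO)NCc1ccc(OCc2cccc(F)c2)cc1` has not yet been measured. It differs from compound 2 by 3-fluorophenyl in place of 4-chlorophenyl on a saturated chain carbon bound to an oxygen on an aromatic ring. For the measured compounds named here, no measured step touches this part of the molecule, so the one known step, which concerns the hydroxy, does not bear on it. What compound 3 shows, a 3-chlorophenyl together with a clearly lower number, cannot be tied to this change alone, since its stereocentre also differs. The expectation for compound 4 is therefore a moderate move toward a lower number, a 2.8-fold lower number from compound 2 to compound 4 (0.44 log units; beyond the scatter), held within a wide range. Compound 4 is estimated at 400 nM, between 100 nM and 1600 nM.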

Compound 4, half-maximal inhibitory concentration: 140 nM
Compound 4: middle estimate off by 2.9-fold (0.46 log units), on the high side, and the stated range covers the measured number.
By their numbers in this assay, from the lowest: compounds 3 and 4 (each within the scatter of the next); then compounds 2 and 1 (each within the scatter of the next).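

Among the compounds shown here, until now, no measured step had touched the aromatic group on a saturated chain carbon bound to an oxygen on an aromatic ring, and in this assay this place responds clearly: 3-fluorophenyl in place of 4-chlorophenyl gives a 7.9-fold lower number from compound 2 to compound 4 (0.90 log units; beyond the scatter) in a single change. For the compounds shown here, the only earlier single-place step, a 2.0-fold lower number from compound 1 to compound 2 (0.30 log units; within the scatter) with a hydroxy added to the chain, stayed within the scatter, so this is the first change in the set that moves the number by more than repeat measurements would be expected to. Nothing available explains why this swap has such an effect, and the result gives only its size and direction.

As far as these compounds go, the swap alters both the halogen and its position on the ring at once, so it remains open which of the two carries the step, and a 4-fluorophenyl at the same place, on the same stereocentre as compound 2, would help to separate them. From the compounds shown here alone, it is also open how an unsubstituted phenyl or a 3-methoxyphenyl would read at this place, which would show whether a halogen is needed there at all.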